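The source may report more compounds than this note shows. Statements on the series, on what has been measured and on what is new or still open speak of the compounds shown alone.

Compound 1 `c1ccc(-c2cnco2)c(NCC2=NCCN2)c1` gives 17.4 nM. Compound 2 `Cc1ncc(-c2ccccc2NCC2=NCCN2)o1` gives 110 nM. Compound 3 `c1csc(-c2ccccc2NCC2=NCCN2)c1` gives 2.24 nM.

In a functional assay for activation of Alpha-1A adrenergic receptor (Homo sapiens), read by calcium flux (a higher number here means that more compound is needed for the effect, a lower number that less compound is needed), compound 2 stands at the highest of the three numbers: the steps of a 6.3-fold higher number from compound 1 to compound 2 (0.80 log units; beyond the scatter) and a 49-fold lower number from compound 2 to compound 3 (1.69 log units; beyond the scatter) both place it above its neighbours. Compound 4 `CCO/N=C(\C)c1ccccc1NCC1=NCCN1` differs from compound 2 by a group of 6 heavy atoms (4 carbon, 1 nitrogen, 1 oxygen; no ring) in place of a group of 6 heavy atoms (4 carbon, 1 nitrogen, 1 oxygen; one five-membered aromatic ring with 2 hetero atoms), on an aromatic carbon. Among the measured compounds shown here, no measured step swaps the ring for an open chain, so the bearing is indirect: the ring exchange a 7.8-fold lower number from compound 1 to compound 3 (0.89 log units; beyond the scatter) and the methyl addition a 6.3-fold higher number from compound 1 to compound 2 (0.80 log units; beyond the scatter) show that this position moves the number modestly. Every measured departure from compound 2 lowered the number, so a modest fall is expected for compound 4, with wide uncertainty, as a 3.1-fold lower number from compound 2 to compound 4 (0.50 log units; beyond the scatter). Compound 4 is estimated at 35 nM, between 8 nM and 150 nM.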

Compound 4, half-maximal effective concentration: 52.5 nM
Estimate against measurement, compound 4: 1.5-fold (0.18 log units) below; low and high end bracket the measured number.
By their numbers in this assay, from the lowest: compound 3; then compound 1; then compound 4; then compound 2.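

In this assay, this aromatic carbon tolerates an open chain with no ring in place of 2-methyl-1,3-oxazol-5-yl, and the number even falls (a 2.1-fold lower number from compound 2 to compound 4 (0.32 log units; beyond the scatter)). The open chain still needs more compound than either ring lacking a methyl (a 3.0-fold higher number from compound 1 to compound 4 (0.48 log units; beyond the scatter)) (a 23-fold higher number from compound 3 to compound 4 (1.37 log units; beyond the scatter)), so the thiophen-2-yl and 1,3-oxazol-5-yl rings keep their lead here. Nothing at hand explains these steps.

The compounds shown leave open how a longer chain on the oxygen would change the number. They also leave open how an amine or a carboxylic acid would fare at this aromatic carbon.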